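Carbamate to aryl amide on the shared core

A few compounds are considered here, and "the series" means these few. Any claim that something is new, unique, unknown or untested is made for them only; others in the source may bear on it.

Measured so far in an assay on LtK cells with ATP-sensitive inward rectifier potassium channel 11 (Homo sapiens) as the target; a higher number here means that more compound is needed for the effect, a lower number that less compound is needed:
compound 1 `CC(C)OC(=O)Nc1c(C(O)(C(F)(F)F)C(F)(F)F)ccc2ccccc12`: 1160 nM
compound 2 `O=C(Nc1c(C(O)(C(F)(F)F)C(F)(F)F)ccc2ccccc12)c1ccccc1`: 44 nM
compound 3 `O=C(Nc1c(C(O)(C(F)(F)F)C(F)(F)F)ccc2ccccc12)c1ccc(I)cc1`: 154 nM

Compound 1 stands highest of the three in this assay, with compound 3 nearest and compound 2 furthest from it. Compound 4 `O=C(Nc1c(C(O)(C(F)(F)F)C(F)(F)F)ccc2ccccc12)c1ccco1` differs from compound 1 in one place: furan-2-yl in place of isopropoxy on a carbonyl carbon. The change sits on a carbonyl carbon whose other neighbours are: amide-type nitrogen. Within the data shown here, two measured steps bear on it, a 26-fold lower number from compound 1 to compound 2 (1.42 log units; beyond the scatter) and a 7.5-fold lower number from compound 1 to compound 3 (0.88 log units; beyond the scatter), both replacing isopropoxy on that carbonyl carbon with a ring and both lowering the number beyond the scatter; the iodo substituent costs part of the gain (a 3.5-fold higher number from compound 2 to compound 3 (0.54 log units; beyond the scatter)). Furan-2-yl is a smaller ring than either, so for compound 4 a large drop is expected, a 15-fold lower number from compound 1 to compound 4 (1.16 log units; beyond the scatter). For compound 4 a value of 80 nM is estimated, within 25 nM to 250 nM.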

Compound 4, half-maximal effective concentration: 9 nM
Estimate against measurement, compound 4: 8.9-fold (0.95 log units) above; the measured number lies below the stated range.
By their numbers in this assay, from the lowest: compound 4; then compound 2; then compound 3; then compound 1.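

Among these compounds, the replacement of isopropoxy on this carbonyl carbon gives its largest step so far with furan-2-yl (a 130-fold lower number from compound 1 to compound 4 (2.11 log units; beyond the scatter)). The identity of the ring matters, not just its presence: furan-2-yl also goes clearly beyond 4-iodophenyl (a 17-fold lower number from compound 3 to compound 4 (1.23 log units; beyond the scatter)) and phenyl (a 4.9-fold lower number from compound 2 to compound 4 (0.69 log units; beyond the scatter)). No measurement here explains the difference between these rings.

Open, going by these compounds, is whether thiophene, pyridine or saturated tetrahydrofuran on the same carbonyl carbon would match compound 4. Also open, on these data alone, is whether a substituent on furan-2-yl would raise the number, as iodo did on phenyl.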